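Toward compound 4: replacing the thiophen-3-yl group

The source may hold more compounds than are shown below. What is called first, only, known or untested is meant among the compounds shown, and "the series" means these compounds.

Measured so far in a functional assay on MOLT-4 cells (Homo sapiens) for antiproliferative activity; a lower number here means a stronger inhibitor, a higher number a weaker inhibitor
compound 1 (`COc1ccc(-c2cc(N)c(C(=O)c3cc(OC)c(OC)c(OC)c3)s2)cc1OC`) gives 20 nM
compound 2 (`COc1cc(C(=O)c2sc(-c3ccc(Cl)cc3)cc2N)cc(OC)c1OC`) gives 77 nM
compound 3 (`COc1cc(C(=O)c2sc(-c3ccsc3)cc2N)cc(OC)c1OC`) gives 8.8 nM

Compound 3 holds the lowest number of the three. The measured steps that end there are a 2.3-fold lower number from compound 1 to compound 3 (0.36 log units; beyond the scatter) and an 8.8-fold lower number from compound 2 to compound 3 (0.94 log units; beyond the scatter) and both count as modest. The next structure is compound 4 (`COc1cc(C(=O)c2sc(-c3ccc(C(F)(F)F)cc3)cc2N)cc(OC)c1OC`), and the change is 4-(trifluoromethyl)phenyl in place of thiophen-3-yl on an aromatic carbon with 4-(trifluoromethyl)phenyl in place of thiophen-3-yl on an aromatic carbon.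

For the measured compounds named here, both phenyl-bearing compounds measured so far sit above compound 3, and none goes against this, though two compounds make a thin pattern. Of the two, compound 2 with its 4-chlorophenyl group is the closer comparison for the entering group. Read backwards, the step from compound 2 therefore points to a modest rise, with compound 4 expected to land near compound 2 at 77 nM in the same assay. The phenyl substituent also matters on its own, as a 3.9-fold higher number from compound 1 to compound 2 (0.59 log units; beyond the scatter) shows. Going by the values given here, no measured compound carries a trifluoromethyl group, so the range stays wide. The expected step is a 9.1-fold higher number from compound 3 to compound 4 (0.96 log units; beyond the scatter) and remains an estimate. In this assay the estimate for compound 4 is 80 nM (expected range 25 nM to 260 nM).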

Compound 4, half-maximal inhibitory concentration: 250 nM
Compound 4: the middle estimate sits 3.1-fold (0.49 log units) below what was measured, and the stated range covers the measured number.
By their numbers in this assay, from the lowest: compound 3; then compound 1; then compound 2; then compound 4.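

In this assay, for the compounds shown here, the group on the aromatic carbon next to the ring sulfur can shift the number much further than the earlier compounds showed: replacing thiophen-3-yl with 4-(trifluoromethyl)phenyl gives a 28-fold higher number from compound 3 to compound 4 (1.45 log units; beyond the scatter) and is a large step. The single substituent on the phenyl ring also counts, since trifluoromethyl in place of chloro gives a 3.2-fold higher number from compound 2 to compound 4 (0.51 log units; beyond the scatter) and the swap from 3,4-dimethoxyphenyl gives a 13-fold higher number from compound 1 to compound 4 (1.10 log units; beyond the scatter), so the three phenyl-bearing compounds now span a wider range, and all three still stand above compound 3, with none going against that order among these four compounds. Nothing measured on these compounds accounts for this order.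

The compounds shown leave open whether the rise with 4-(trifluoromethyl)phenyl belongs to that particular substituent or would also appear with a 4-methoxyphenyl, a 4-cyanophenyl or an unsubstituted phenyl group. They also leave open whether the low number of compound 3 8.8 nM extends to other five-membered aromatic rings, such as thiophen-2-yl or furan-3-yl, or to a six-membered ring carrying an amine.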